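This account rests on a few compounds, and the source may have more. Where it says the series, first, only, none or still open, it means among the compounds named here.

Series notes. In an assay on CHO cells for displacement of a labelled ligand from 5-hydroxytryptamine receptor 7 (Homo sapiens), read by scintillation counting, with a stated time of 60 min (on this read-out lower numbers stand for stronger inhibition and higher numbers for weaker inhibition), compound 1 `COc1ccc(/C=C2\NC(=O)N(CCCN3CCN(c4ccccc4OC)CC3)C2=O)cc1OC1CCCC1` gives 6 nM. Compound 2 `COc1ccc(/C=C2\NC(=O)N(CCCN3CCN(c4cccc(Cl)c4Cl)CC3)C2=O)cc1OC1CCCC1` differs from compound 1 by 2,3-dichlorophenyl in place of 2-methoxyphenyl on an amine nitrogen in a ring; in this assay compound 2 gives 380 nM, which is a 63-fold higher number from compound 1 to compound 2 (1.80 log units; beyond the scatter). Going by the values given here, compound 3 `COc1ccc(/C=C2\NC(=O)N(CCCCN3CCN(c4ccccc4OC)CC3)C2=O)cc1OC1CCCC1` carries a different core from compound 1, and the difference between the two cores is not broken down here; in this assay compound 3 gives 1 nM, the lowest number of the three measured so far. Compound 4 `COc1ccc(/C=C2\NC(=O)N(CCCCN3CCN(c4cccc(Cl)c4Cl)CC3)C2=O)cc1OC1CCCC1` differs from compound 3 by 2,3-dichlorophenyl in place of 2-methoxyphenyl on an amine nitrogen in a ring, the same change, at the same place, as between compound 1 and compound 2. In this assay, among the compounds with values here, the expected step is a 60-fold higher number from compound 3 to compound 4 (1.78 log units; beyond the scatter), because the one measured instance of this change gave a 63-fold higher number from compound 1 to compound 2 (1.80 log units; beyond the scatter). Compound 4 is accordingly estimated at 60 nM in this assay, with an expected range from 20 nM to 200 nM.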

Compound 4, inhibition constant: 125 nM
Compound 4: middle estimate off by 2.1-fold (0.32 log units), on the low side; the measured number falls inside the stated range.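

In this assay 2,3-dichlorophenyl in place of 2-methoxyphenyl gives a 130-fold higher number from compound 3 to compound 4 (2.10 log units; beyond the scatter) and so repeats the large step seen on the core of compound 1. The two instances of this change agree in size: the same change on two cores in this assay, a 63-fold higher number (1.80 log units; beyond the scatter) from compound 1 to compound 2 and a 130-fold higher number (2.10 log units; beyond the scatter) from compound 3 to compound 4, 2.0-fold (0.30 log units) apart, within the scatter of two such steps. This shows that the change carries over between these two cores, but two cores do not establish that it holds on any other core, and the numbers do not show why the step arises.

Still open, on these data alone, is whether a plain phenyl or a 2-chlorophenyl on the ring nitrogen falls closer to the 2-methoxyphenyl or to the 2,3-dichlorophenyl compounds. Also open, as far as these compounds go, is whether the step keeps its size with a pentyl chain on the shared core.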